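Series notes: compound 1 to compound 4

This account rests on a few compounds, and the source may have more. Where it says the series, first, only, none or still open, it means among the compounds named here.

Measured so far:
- compound 1 `CC(C)=C1C(=O)Nc2ccc(OCc3ccc(F)cc3)cc21`: "not active" (no number reported)
- compound 2 `CC1(C)C(=O)Nc2ccc(OCc3ccc(F)cc3)cc21`: "not active" (no number reported)
- compound 3 `Cn1c(=O)[nH]c2cc(OCc3cccc(Cl)c3)ccc21`: 23.4%

In an assay on cells for inhibition of Amine oxidase [flavin-containing] B (Homo sapiens), read by fluorescence, with stated times of 30 min and 15 min, tested at 1 uM (on this read-out higher numbers stand for more inhibition at the one concentration tested (going by the name of the read-out) and lower numbers for less inhibition), compound 1 gives "not active" (no number reported), a report with no single number. Compound 2 is reported the same way in this assay, with "not active" (no number reported). For the measured compounds named here, only compound 3 carries a number in this assay, 23.4%, and it has a different core and a different halogen, so no step to compound 1 can be drawn from it. Going by the values given here, compound 1 thus stands without a numeric value, and no step between measured compounds is available in this assay.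

Compound 4 `CC(C)=C1C(=O)Nc2ccc(OCc3cccc(F)c3)cc21` differs from compound 1 in one place: 3-fluorophenyl in place of 4-fluorophenyl on a saturated chain carbon bound to an oxygen on an aromatic ring. Among the compounds with values here, with no measured step to lean on, the expectation is for no change beyond the scatter in either direction; the single number on compound 3 does not fix a direction for this change. Compound 4 is estimated at 12%, with a range from 0% to 35%, and a real chance that this assay again reports no number.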

Compound 4, a percentage reported as inhibition, at one concentration (the size of the read-out at that concentration, not a potency): "not active" (no number reported)
Compound 4: no number reported, so the estimate cannot be set against anything.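

In this assay, for the compounds shown here, compound 1 gives "not active" (no number reported) and compound 4 gives "not active" (no number reported), and no step between the two can be read. No measurement shown bears on this result. As far as these compounds go, whether 3-fluorophenyl in place of 4-fluorophenyl shifts inhibition in either direction remains open.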